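The source may report more compounds than this note shows. Statements on the series, on what has been measured and on what is new or still open speak of the compounds shown alone.

Measured so far in an assay for inhibition of acid-sensing ion channel 3 (Homo sapiens), read by patch clamp, tested at 20 uM; a higher number here means more inhibition at the concentration tested (going by the name of the read-out), a lower number less inhibition:
- compound 1, `NC(N)=NC(=O)c1nc(Cl)c(N2CCCCC2)nc1N`: 85%
- compound 2, `CSc1nc(N)c(C(=O)N=C(N)N)nc1Cl`: "not determined" (no result reported)

Compound 2 stands on no number at all: in this assay it has no reported value, so nothing shows whether it inhibits strongly, weakly or not at all. Within the data shown here, compound 1, which shares the core with it, gives 85% in this assay, and that single value is the only measured guide to what this core can do.

The step from compound 2 leads to compound 3, `NC(N)=NC(=O)c1nc(Cl)c(Oc2ccccc2)nc1N`. The change is phenoxy in place of methylsulfanyl on an aromatic carbon. Since compound 2 has no number, no step size and no direction relative to it can be given, and nothing tells whether the move is within or beyond the scatter.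

Compound 3 is expected to give about 65% in this assay, with a range from 30% to 95%.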

Compound 3, a percentage reported as inhibition, at one concentration (the size of the read-out at that concentration, not a potency): 90%
Compound 3: the middle estimate sits 25 percentage points below what was measured; measured number inside the range.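

In this assay, putting phenoxy in place of piperidin-1-yl on this aromatic carbon gives a number 5 percentage points higher from compound 1 to compound 3 (within the scatter). This position of the shared core can therefore carry either of two quite different six-membered rings, one joined through oxygen and the other through nitrogen, without a change that stands out from the scatter. No measurement shown offers an explanation for this match between the two groups.

Compound 2 has no number, so it remains unclear whether the much smaller methylsulfanyl group can serve at this position as well as the two ring-bearing groups. On these data alone, it is also open how a plain amine, a carboxylic acid or a longer carbon chain on this carbon would fare, and whether any such group would move the result beyond the scatter.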